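The source may hold more compounds than are shown below. What is called first, only, known or untested is meant among the compounds shown, and "the series" means these compounds.

Among the measured compounds shown here, in an ADME assay on KB cells (Homo sapiens) for cytotoxicity, read by MTT assay, with a stated time of 72 h (a higher number here means that more compound is tolerated, a lower number that less compound is tolerated), compound 1 `FC(F)(F)c1ccc(-c2csc(Nc3ccc(Cl)cn3)n2)nc1` gives 35400 nM and compound 2 `CCOc1ccc(-c2csc(Nc3ccc(Cl)cn3)n2)nc1` gives 2700 nM, the lower of the two numbers so far. Compound 3 `CCOc1ccc(-c2nc(Nc3ccc(Cl)cn3)sc2Cl)nc1` has chloro in place of hydrogen on an aromatic carbon. For the measured compounds named here, the only measured step, a 13-fold lower number from compound 1 to compound 2 (1.12 log units; beyond the scatter), is large, but it exchanges different groups at a different place, so it sets no size for this change. No step beyond the scatter is expected, with a slightly lower number as the likelier direction: the estimated change is a 1.4-fold lower number from compound 2 to compound 3 (0.13 log units; within the scatter). For compound 3 the expected value is 2000 nM, with an estimated range of 700 nM to 6000 nM.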

Compound 3, half-maximal cytotoxic concentration in the KB assay: 12100 nM
Estimate against measurement, compound 3: 6.1-fold (0.78 log units) below, and the stated range ends below it.
By their numbers in the KB assay, from the lowest: compound 2; then compound 3; then compound 1.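

In the KB assay, chloro in place of hydrogen on an aromatic carbon next to the ring sulfur gives a 4.5-fold higher number from compound 2 to compound 3 (0.65 log units; beyond the scatter). This position, which carries hydrogen in both earlier compounds, therefore does bear on the read-out, and the change here goes towards more compound tolerated. In a physicochemical assay for solubility, in phosphate buffer, with a stated time of 2 h, at pH 7.4 (on this read-out lower numbers stand for lower solubility and higher numbers for higher solubility), compound 2 gives < 10000 nM as a limit of the assay and not a number. In the physicochemical assay compound 3 gives < 10000 nM as a limit of the assay and not a number. In the physicochemical assay the step cannot be read, and no solubility change can be assigned to chloro: the limit of < 10000 nM in the physicochemical assay, at which 2 of the 2 values shown sit.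

Going by these compounds, whether an amine or a methyl at this position would move the number the same way stays open. So does whether chloro acts alike with trifluoromethyl in place of ethoxy.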